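Phenol-for-methoxy swap on the shared core

The compounds below may be only part of what the source reports. "The series", "measured", "known", "first", "only" and "open" are said of these compounds alone.

compound 1 `Cc1cc(O)cc(-c2nn(CC#N)cc2-c2ccnc(-c3ccc(Oc4ccccc4)cc3)c2)c1` — in a functional assay on EKVX cells (Homo sapiens) for inhibition, read by sulforhodamine B assay, with a stated time of 48 h (a higher number here means that more compound is tolerated, a lower number that less compound is tolerated), compound 1 gives > 100000 nM, a limit of the assay.
compound 2 `COc1cc(C)cc(-c2nn(CC#N)cc2-c2ccnc(-c3ccc(N(C)C)cc3)c2)c1` — in this assay compound 2 gives > 100000 nM, a limit of the assay.

Compound 2 stands at the limit of > 100000 nM in this assay, at which 2 of the 2 values shown sit. Its value in this assay is a limit and not a number. Among the measured compounds shown here, compound 1 is likewise reported only as a limit, so no order between the two can be read, and no measured step on the shared core exists to size the change.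

The unmeasured compound 3 `Cc1cc(O)cc(-c2nn(CC#N)cc2-c2ccnc(-c3ccc(N(C)C)cc3)c2)c1` differs from compound 2 by hydrogen in place of methyl on an oxygen on an aromatic ring; it thus carries the 3-hydroxy-5-methylphenyl of compound 1 together with the dimethylamino-bearing side of compound 2.

With both neighbours at the limit, the expected step in this assay is none beyond the scatter, a step that the limit leaves unreadable from compound 2 to compound 3, in no preferred direction. Compound 3 is therefore estimated at 150000 nM, with a range from 70000 nM to 400000 nM, and the assay is expected most likely to report only a limit again.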

Compound 3, concentration lethal to 50% of the cells: > 100000 nM
Compound 3 gave a limit, no number; the forecaster's own chance of this, stated with the estimate: 85%; the middle value is on the limit's open side.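

In this assay compound 3 gives > 100000 nM, a limit of the assay. Compound 1 and compound 2 are also reported only as limits, and neither of their steps to compound 3 can be read: the limit of > 100000 nM in this assay, at which 3 of the 3 values shown sit.

Still open, as far as these compounds go, is whether methoxy to hydroxy or phenoxy to dimethylamino changes the concentration lethal to the cells at all.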